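Changing the sulfonyl aryl group of a serotonin receptor ligand

The source may report more compounds than this note shows. Statements on the series, on what has been measured and on what is new or still open speak of the compounds shown alone.

Compound 1 `COc1cc(N)c(Cl)cc1C(=O)CCC1CCN(CCNS(=O)(=O)c2cc(Br)ccc2Br)CC1` gives 16.3 nM in an assay on brain for displacement of a labelled ligand from 5-hydroxytryptamine receptor 4 (Cavia porcellus), with a stated time of 30 min, in the presence of a further agent that is not named here (a lower number here means a stronger inhibitor, a higher number a weaker inhibitor), the highest of the three numbers shown so far. In this assay compound 2 `COc1ccc(S(=O)(=O)NCCN2CCC(CCC(=O)c3cc(Cl)c(N)cc3OC)CC2)cc1OC` gives 8.2 nM, and compound 3 `COc1cc(N)c(Cl)cc1C(=O)CCC1CCN(CCNS(=O)(=O)c2ccc(N)c(Br)c2)CC1` gives 5.3 nM. Compound 4 `COc1cc(N)c(Cl)cc1C(=O)CCC1CCN(CCNS(=O)(=O)c2ccc(NC(C)=O)cc2)CC1` has not yet been measured; it differs from compound 1 in one place: 4-acetamidophenyl in place of 2,5-dibromophenyl on a sulfonyl sulfur. Two measured steps alter the same group on the sulfonyl sulfur: a 2.0-fold lower number from compound 1 to compound 2 (0.30 log units; within the scatter), and a 3.1-fold lower number from compound 1 to compound 3 (0.49 log units; beyond the scatter). Both replacements of the 2,5-dibromophenyl left the number unchanged or modestly lower, so for compound 4 a modest lower number is expected, a 2.3-fold lower number from compound 1 to compound 4 (0.37 log units; beyond the scatter). Compound 4 is therefore estimated at 7 nM, with a likely range from 3 nM to 18 nM.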

Compound 4, inhibition constant: 7.7 nM
Beside the measured number, compound 4's estimate is 1.1-fold (0.04 log units) below it; the measured number falls inside the stated range.
By their numbers in this assay, from the lowest: compounds 3, 4, 2 and 1 (each within the scatter of the next, the first and the last beyond it).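

Compound 4 carries an acetamide rather than bromine, and it is the second replacement of the 2,5-dibromophenyl to move the number beyond the scatter (a 2.1-fold lower number from compound 1 to compound 4 (0.33 log units; beyond the scatter)). The three replacements stay close, with (a 1.5-fold higher number from compound 3 to compound 4 (0.16 log units; within the scatter)) and (a 1.1-fold lower number from compound 2 to compound 4 (0.03 log units; within the scatter)) both within the scatter, so this sulfonyl position admits quite different aryl groups without separating them. No evidence here bears on this result.

Still open, on these data alone, is how an unsubstituted phenyl, a carboxylic acid or a longer chain carrying an amine would behave on the sulfonyl sulfur.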